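Swapping the Carbamoyl Side Group for Hydrogen

The compounds below may be only part of what the source reports. "The series", "measured", "known", "first", "only" and "open" are said of these compounds alone.

Of the compounds shown here, three sharing one core have been tested in a functional assay on the whole organism (Tail, strain ICR) with Mus musculus as the target, in the tail flick test, with a stated time of 90 min, at a dose of 25 umol/kg by the oral route; a higher number here means a stronger effect of the compound at the dose given, a lower number a weaker effect. Compound 1, `O=C(CN(c1nc(Cl)nc2[nH]cnc12)C1CC1)N[C@@H](CCC(=O)OCc1ccccc1)C(=O)OCc1ccccc1`, gives 50%. Compound 2, `NC(=O)C[C@H](NC(=O)CN(c1nc(Cl)nc2[nH]cnc12)C1CC1)C(=O)O`, gives 20.1%. Compound 3, `CCOC(=O)CN(c1nc(Cl)nc2c1ncn2C1CCCCO1)C1CC1`, gives 13%. Among these three numbers, compound 2 stands second highest: its nearest neighbour is compound 3, whose number lies within the usual scatter of repeated measurements, so the two cannot be told apart; the furthest is compound 1, whose number lies beyond the scatter and so marks a real difference.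

Compound 4, `C[C@H](NC(=O)CN(c1nc(Cl)nc2[nH]cnc12)C1CC1)C(=O)O`, has not yet been measured. Compared with compound 2, the change is hydrogen in place of carbamoyl on a saturated chain carbon, two bonds along the chain from an amide-type nitrogen and a carbonyl carbon.

Going by the values given here, no measured pair shows this particular change, so its effect is unknown. The acid-bearing chain remains, and the rest of the molecule is unchanged, so the expectation is a step in this assay of no more than the scatter, in either direction. Compound 4 is therefore expected to give 18%, with a plausible range from 5% to 35%. This estimate corresponds to an expected step of a number 2.1 percentage points lower from compound 2 to compound 4 (within the scatter), small compared with the scatter.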

Compound 4, a percentage reported as activity, at one dose (the size of the read-out at that dose, not a potency): 43.5%
The estimate for compound 4 lay 25.5 percentage points below the measured number; the whole stated range lies below it.
By their numbers in this assay, from the lowest: compounds 3 and 2 (each within the scatter of the next); then compounds 4 and 1 (each within the scatter of the next).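

In this assay the saturated chain carbon, two bonds along the chain from an amide-type nitrogen and a carbonyl carbon, proves to be a place where a single change counts: hydrogen in place of carbamoyl gives a number 23.4 percentage points higher from compound 2 to compound 4 (beyond the scatter) with the rest of the molecule untouched. Going by these compounds alone, the earlier compounds differed from one another in more than one place, so this pair is the first to isolate the effect of one group, and it shows that carbamoyl is not required for the effect seen at this dose; the compound carrying the shorter methyl side group does better here than the one carrying carbamoylmethyl. Nothing available explains why the number rises with this change.

This single pair cannot show whether carbamoyl itself holds the number down or whether any larger group at this place would do the same, and an aminomethyl group, a hydroxymethyl group or a plain ethyl chain at the same carbon would help to separate those readings. The step also comes from one dose at one time point, so it describes the size of the effect there and not a potency.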